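Extending the linker of a para-linked hydroxamate on a macrolide

The compounds below may be only part of what the source reports. "The series", "measured", "known", "first", "only" and "open" are said of these compounds alone.

Compound 3 `CC[C@H]1OC(=O)[C@H](C)C(=O)[C@H](C)[C@@H](O[C@@H]2O[C@H](C)C[C@H](N(C)Cc3ccc(-c4cn(CCC(=O)NO)nn4)cc3)[C@H]2O)[C@@](C)(OC)C[C@@H](C)C2=NCCN3C(=O)O[C@@]1(C)[C@H]3[C@H]2C` is one of three analogues that share a macrolide core and a hydroxamic acid tethered through a triazole. In an assay for inhibition of histone deacetylase 8 (Homo sapiens), read by mass spectrometry, with a stated time of 60 min (on this read-out higher numbers stand for weaker inhibition and lower numbers for stronger inhibition), compound 3 reaches only the limit of the assay, > 10000 nM. That limit is the limit of > 10000 nM in this assay, at which 1 of the 3 values shown sits. The two compounds with numbers are compound 1 `CC[C@H]1OC(=O)[C@H](C)C(=O)[C@H](C)[C@@H](O[C@@H]2O[C@H](C)C[C@H](N(C)Cc3ccccc3-c3cn(CCCCCC(=O)NO)nn3)[C@H]2O)[C@@](C)(OC)C[C@@H](C)C2=NCCN3C(=O)O[C@@]1(C)[C@H]3[C@H]2C`, which in this assay gives 1190 nM, and compound 2 `CC[C@H]1OC(=O)[C@H](C)C(=O)[C@H](C)[C@@H](O[C@@H]2O[C@H](C)C[C@H](N(C)Cc3ccccc3-c3cn(CCCCCCC(=O)NO)nn3)[C@H]2O)[C@@](C)(OC)C[C@@H](C)C2=NCCN3C(=O)O[C@@]1(C)[C@H]3[C@H]2C`, which gives 2450 nM; their difference is a 2.1-fold higher number from compound 1 to compound 2 (0.31 log units; beyond the scatter). Compound 4 `CC[C@H]1OC(=O)[C@H](C)C(=O)[C@H](C)[C@@H](O[C@@H]2O[C@H](C)C[C@H](N(C)Cc3ccc(-c4cn(CCCCC(=O)NO)nn4)cc3)[C@H]2O)[C@@](C)(OC)C[C@@H](C)C2=NCCN3C(=O)O[C@@]1(C)[C@H]3[C@H]2C` differs from compound 3 by 2-(hydroxycarbamoyl)ethyl in place of hydroxycarbamoyl on a saturated chain carbon, two bonds along the chain from an aromatic nitrogen. For the measured compounds named here, the only measured step, from compound 1 to compound 2, lengthens the tether by one carbon on a differently substituted benzyl group, so it bears on this change only loosely, and there it ran toward a weaker number. Compound 3 sits at a limit. The step from compound 3 to compound 4 is expected to be an at least 2.8-fold lower number from compound 3 to compound 4 (0.45 log units; beyond the scatter), reasoned from compound 1 with its 1190 nM at a comparable tether length. Compound 4 is therefore estimated at 3500 nM, within 900 nM to 12000 nM.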

Compound 4, half-maximal inhibitory concentration: 3210 nM
Compound 4: middle estimate off by 1.1-fold (0.04 log units), on the high side, and the stated range covers the measured number.
By their numbers in this assay, from the lowest: compound 1; then compounds 2 and 4 (each within the scatter of the next). At a limit, above all of these: compound 3.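

In this assay, 2-(hydroxycarbamoyl)ethyl in place of hydroxycarbamoyl on a saturated chain carbon, two bonds along the chain from an aromatic nitrogen, gives an at least 3.1-fold lower number from compound 3 to compound 4 (0.49 log units; beyond the scatter). The only earlier lengthening, a 2.1-fold higher number from compound 1 to compound 2 (0.31 log units; beyond the scatter), ran toward a higher number on a differently substituted benzyl group, so the compounds shown give no single direction for a longer chain. Compound 3 stands at a limit rather than at a number, so the full size of the new step cannot be read: the limit of > 10000 nM in this assay, at which 1 of the 4 values shown sits.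

The compounds shown leave open whether the number would keep falling with a still longer chain in this series, or how a chain of intermediate length would compare. They also leave open whether a carboxylic acid at the chain end, in place of the hydroxycarbamoyl group, would show any inhibition.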